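Methylsulfanyl to hydroxy: an expected step in growth inhibition

A few compounds are considered here, and "the series" means these few. Any claim that something is new, unique, unknown or untested is made for them only; others in the source may bear on it.

Compound 1 `CCOC(=O)C1=C(C)NC(=O)NC1c1ccc(SC)cc1` gives 10 ug/mL
Compound 2 `CCCc1ccc(C2NC(=S)NC(C)=C2C(=O)OCC)cc1` gives 38.1 ug/mL

In a functional assay on OVCAR-3 cells (Homo sapiens) for inhibition, read by sulforhodamine B assay, with a stated time of 48 h (on this read-out higher numbers stand for weaker inhibition of growth and lower numbers for stronger inhibition of growth), compound 1 holds the lower of the two numbers at 10 ug/mL and compound 2 stands higher at 38.1 ug/mL with a gap beyond the scatter. The next compound to be measured is compound 3 `CCOC(=O)C1=C(C)NC(=O)NC1c1ccc(O)cc1`, which keeps the core of compound 1 and carries hydroxy in place of methylsulfanyl on an aromatic carbon. Going by the values given here, no two measured compounds differ in one place only, so the data offer no direct guide to the size of this change. With compound 1 at 10 ug/mL as the lower of the two numbers, a move toward a higher number in this assay is expected rather than a move toward a lower one. The estimated size is a 2.2-fold higher number from compound 1 to compound 3 (0.34 log units; beyond the scatter) and it remains uncertain. For compound 3 the estimate is 22 ug/mL with an expected range of 8 ug/mL to 60 ug/mL on the same read-out.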

Compound 3, concentration for 50% growth inhibition: 27.3 ug/mL
Beside the measured number, compound 3's estimate is 1.2-fold (0.09 log units) below it, and the stated range covers the measured number.
By their numbers in this assay, from the lowest: compound 1; then compounds 3 and 2 (each within the scatter of the next).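

In this assay the exchange of methylsulfanyl for hydroxy, on an aromatic carbon para to a large group, gives a 2.7-fold higher number from compound 1 to compound 3 (0.44 log units; beyond the scatter) and provides the only single-place comparison among the compounds shown. The step is modest but beyond the scatter, so growth inhibition at this position does depend on which of these two groups is present, and methylsulfanyl gives the lower number. Nothing available explains why the number rises with this exchange.

Compound 2 differs from both compounds in more than one place, so it cannot help to separate this change from others. Going by these compounds, whether a methoxy group, an amine or a longer chain at the same position would give a number nearer that of compound 1 or that of compound 3 remains open.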